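Swapping the amide substituent of compound 2 for a pyridin-2-yl group

The compounds below may be only part of what the source reports. "The series", "measured", "known", "first", "only" and "open" are said of these compounds alone.

Measured compounds and their values in a functional assay on K562 cells (Homo sapiens) for cytotoxicity, read by MTT assay, with a stated time of 72 h; on this read-out lower numbers stand for stronger inhibition and higher numbers for weaker inhibition:
- compound 1 `C#CCn1cc(C(=O)NC(CC(=O)Nc2ccccc2)c2ccccc2)c(=O)c2cccnc21`: compound 1 reads > 10000 nM, a limit of the assay
- compound 2 `C#CCn1cc(C(=O)NC(CC(=O)NC2CCCC2)c2ccccc2)c(=O)c2cc(F)c(Cl)nc21`: compound 2 gives 7300 nM
- compound 3 `C#CCn1cc(C(=O)NC(CC(=O)NC2CCCCC2)c2ccccc2)c(=O)c2cc(F)c(Cl)nc21`: compound 3 gives 6200 nM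

Three compounds share a core and differ in the group on an amide-type nitrogen. For compound 1 the reading is only a limit of this assay, not a number. Among the two real numbers, compound 2 stands highest, and the only measured step, a 1.2-fold lower number from compound 2 to compound 3 (0.07 log units; within the scatter), lies within the scatter, so compounds 2 and 3 cannot be told apart on these data.

Compound 4 `C#CCn1cc(C(=O)NC(CC(=O)Nc2ccccn2)c2ccccc2)c(=O)c2cc(F)c(Cl)nc21` is not yet measured. Its difference from compound 2 is pyridin-2-yl in place of cyclopentyl on an amide-type nitrogen. Among the compounds with values here, no measured step bears directly on this change: the one step that exists, from cyclopentyl to cyclohexyl, is small and within the scatter, and compound 1 carries a different core and only a limit, so it offers no comparison. The expectation for compound 4 is therefore a step of about a 1.1-fold higher number from compound 2 to compound 4 (0.04 log units; within the scatter) in this assay, that is, no change beyond the scatter. Compound 4 is estimated at 8000 nM, with a range from 3000 nM to 20000 nM.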

Compound 4, half-maximal inhibitory concentration: > 10000 nM
Compound 4 was reported as a limit (the forecaster's own chance of this, stated with the estimate: 35%); middle value at least 1.2-fold (0.09 log units) from the limit.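

In this assay, compound 4, which carries pyridin-2-yl on the amide-type nitrogen, gives > 10000 nM, a limit and not a number. Going by these compounds, replacing a non-aromatic carbon ring with this aromatic ring, which adds one ring nitrogen and one hydrogen-bond acceptor, gives an at least 1.3-fold higher number from compound 2 to compound 4 (0.13 log units; that floor lies within the scatter) and an at least 1.6-fold higher number from compound 3 to compound 4 (0.20 log units; that floor lies within the scatter), so these floors alone do not establish a real loss, and the full size of the change remains unknown. The earlier pair only exchanged one non-aromatic carbon ring for another, whereas this result shows that, on the core shared by compounds 2, 3 and 4, pyridin-2-yl gives no measurable value and the reading stops at the assay's ceiling: the limit of > 10000 nM in this assay, at which 2 of the 4 values shown sit.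

The compounds shown leave open whether any group on this nitrogen can bring the number well under those of compounds 2 and 3. A benzyl group or an open butyl chain on the same core would test whether a ring directly on this nitrogen is needed at all, and whether the outcome for compound 4 extends to other groups.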